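Chloro for Hydrogen: Does the Pattern Carry Across Cores?

The compounds below may be only part of what the source reports. "The series", "measured", "known", "first", "only" and "open" are said of these compounds alone.

Compound 1 `C/C(=N\O)c1ccc2[nH]c(-c3ccccc3)nc2c1` and compound 2 `C/C(=N\O)c1ccc2[nH]c(-c3ccc(Cl)cc3)nc2c1` share one core and differ only in that compound 2 carries chloro in place of hydrogen on an aromatic carbon. In an ADME assay on MDBK cells (Bos taurus) for cytotoxicity, read by MTT assay, with a stated time of 96 h (on this read-out higher numbers stand for lower toxicity in this test and lower numbers for higher toxicity in this test), compound 1 gives only a limit of the assay, > 100000 nM. In this assay compound 2 gives 37000 nM. Among the compounds with values here, the step of an at least 2.7-fold lower number from compound 1 to compound 2 (0.43 log units; beyond the scatter) is thus read from a limit on one side, and it is the only measured instance of this change.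

Compound 3 `CC(=O)c1ccc2c(c1)nc(-c1ccccc1)n2C1CCCCC1` rests on a different core; the difference between the cores of compound 1 and compound 3 is not broken down here. In this assay compound 3 gives only a limit, > 100000 nM. That is the limit of > 100000 nM in this assay, at which 2 of the 3 values shown sit.

Compound 4 `CC(=O)c1ccc2c(c1)nc(-c1ccc(Cl)cc1)n2C1CCCCC1` differs from compound 3 by chloro in place of hydrogen on an aromatic carbon, the same change as that between compound 1 and compound 2, at a place described in the same words. Within the data shown here, the only guide to its size is the step of an at least 2.7-fold lower number from compound 1 to compound 2 (0.43 log units; beyond the scatter). Because compound 3 sits at the limit of > 100000 nM in this assay, at which 2 of the 3 values shown sit, any number expected for compound 4 can only be read downward from that limit. Compound 4 is therefore expected to come out near 45000 nM in this assay, with a range estimated from 15000 nM to 100000 nM, and with a real chance that this assay again reports only a limit. For compound 4 this estimate means an expected step of an at least 2.2-fold lower number from compound 3 to compound 4 (0.34 log units; beyond the scatter).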

Compound 4, half-maximal cytotoxic concentration: > 100000 nM
Compound 4 was reported as a limit (the forecaster's own chance of this, stated with the estimate: 40%); middle value at least 2.2-fold (0.34 log units) away from the limit.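

In this assay compound 4 gives only a limit, > 100000 nM. Compound 3 also gives only a limit, so no step can be read between compound 3 and compound 4: the limit of > 100000 nM in this assay, at which 3 of the 4 values shown sit.

The compounds shown leave open whether chloro in place of hydrogen changes the number at all on the core of compound 3, as it does on the core of compound 1.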